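Swapping the Aryl Ether: From Hydroxyphenyl to Methylthiophenyl

A few compounds are considered here, and "the series" means these few. Any claim that something is new, unique, unknown or untested is made for them only; others in the source may bear on it.

Measured compounds:
- Compound 1 `CC[C@@H]1/C=C(\C)C[C@H](C)C[C@H](OC)[C@H]2O[C@@](O)(C(=O)C(=O)N3CCCC[C@H]3C(=O)O[C@H](/C(C)=C/[C@@H]3CC[C@@H](Oc4cccc(O)c4)[C@H](OC)C3)[C@H](C)[C@@H](O)CC1=O)[C@H](C)C[C@@H]2OC` gives 1.7 nM in a functional assay on cells for inhibition, with Murine T-cell line (Mus musculus) as the target; a higher number here means a weaker inhibitor, a lower number a stronger inhibitor.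
- Compound 2 `CC[C@@H]1/C=C(\C)C[C@H](C)C[C@H](OC)[C@H]2O[C@@](O)(C(=O)C(=O)N3CCCC[C@H]3C(=O)O[C@H](/C(C)=C/[C@@H]3CC[C@@H](Oc4ccc(OC)cc4)[C@H](O)C3)[C@H](C)[C@@H](O)CC1=O)[C@H](C)C[C@@H]2OC` gives 1.2 nM in this assay.
- Compound 3 `CC[C@@H]1/C=C(\C)C[C@H](C)C[C@H](OC)[C@H]2O[C@@](O)(C(=O)C(=O)N3CCCC[C@H]3C(=O)O[C@H](/C(C)=C/[C@@H]3CC[C@@H](Oc4cc(C(F)(F)F)cc(C(F)(F)F)c4)[C@H](OC)C3)[C@H](C)[C@@H](O)CC1=O)[C@H](C)C[C@@H]2OC` gives 607 nM in this assay.

All three share one large core and differ only in the aromatic ring hung on the ether oxygen. Compound 1 sits with compound 2 at the low end of the numbers; the gap between them lies within the scatter, so no order can be read between the two. Compound 3 stands far higher, well beyond the scatter, and is clearly the weaker inhibitor of the three.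

Compound 4 `CC[C@@H]1/C=C(\C)C[C@H](C)C[C@H](OC)[C@H]2O[C@@](O)(C(=O)C(=O)N3CCCC[C@H]3C(=O)O[C@H](/C(C)=C/[C@@H]3CC[C@@H](Oc4ccc(SC)cc4)[C@H](OC)C3)[C@H](C)[C@@H](O)CC1=O)[C@H](C)C[C@@H]2OC` has not yet been measured. It differs from compound 1 in one place: 4-(methylsulfanyl)phenyl in place of 3-hydroxyphenyl on an oxygen on a saturated carbon. For the measured compounds named here, no measured pair shows exactly this exchange, so the expectation rests on the spread seen so far. Because compound 1 gives 1.7 nM and compound 2 gives 1.2 nM while only compound 3 gives 607 nM, a small step is expected, estimated at a 1.8-fold higher number from compound 1 to compound 4 (0.25 log units; within the scatter), toward a somewhat higher number but most likely within the scatter. Compound 4 is therefore expected to give about 3 nM, estimated between 1 nM and 15 nM.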

Compound 4, half-maximal inhibitory concentration: 2.6 nM
Estimate against measurement, compound 4: 1.2-fold (0.06 log units) above; the range from low to high includes it.
By their numbers in this assay, from the lowest: compounds 2, 1 and 4 (each within the scatter of the next, the first and the last beyond it); then compound 3.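

For the compounds shown here, compound 4 gives the first direct reading of a single change at this ether position: in this assay, 4-(methylsulfanyl)phenyl in place of 3-hydroxyphenyl gives a 1.5-fold higher number from compound 1 to compound 4 (0.18 log units; within the scatter), a step too small to count as a real change. So, in this pair, the aromatic ring on the ether oxygen can lose the hydrogen-bond donor of 3-hydroxyphenyl and take on a sulfur-bearing group with no clear loss of inhibition. Nothing measured here explains why the number holds steady.

This one exchange alters both the group and its place on the ring, so the contribution of each remains unresolved. On these data alone, it also remains open how this position would respond to a ring carrying an amine or a carboxylic acid.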